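Swapping a chlorophenyl for a methylpyridinyl on a cytotoxic core

The source may report more compounds than this note shows. Statements on the series, on what has been measured and on what is new or still open speak of the compounds shown alone.

Measured compounds:
- compound 1, `CC/C(=C(/c1ccc(/C=C/C(=O)O)cc1)c1cccc2[nH]ncc12)c1ccccc1`: 21 nM
- compound 2, `CC/C(=C(/c1ccc(/C=C/C(=O)O)cc1)c1ccc2[nH]ncc2c1)c1ccccc1Cl`: 2 nM

In a functional assay on MCF7 cells (Homo sapiens) for cytotoxicity, read by CellTiter-Glo, with a stated time of 5 days (a lower number here means a stronger inhibitor, a higher number a weaker inhibitor), compound 2 gives 2 nM, the lowest of the two numbers seen so far. Within the data shown here, compound 1, the only other measured compound, gives a higher number, and that gap lies beyond the usual scatter; the two differ in more than one place, so no single step connects them.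

Among the measured compounds shown here, compound 3, `CC/C(=C(/c1ccc(/C=C/C(=O)O)cc1)c1ccc2[nH]ncc2c1)c1cccnc1C`, keeps the core of compound 2 and changes only one group: 2-methylpyridin-3-yl in place of 2-chlorophenyl on a double-bonded chain carbon bound to a double-bonded chain carbon and a saturated chain carbon. For the measured compounds named here, no measured pair shows this exact change, so the expectation rests on compound 2 alone. The group that leaves and the group that enters are of the same size, and a small rise in the number, possibly within the scatter, is expected: a 2.0-fold higher number from compound 2 to compound 3 (0.30 log units; within the scatter). Compound 3 is therefore estimated at 4 nM in this assay, with a range from 1 nM to 15 nM.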

Compound 3, half-maximal inhibitory concentration: 200 nM
For compound 3 the middle estimate is 50-fold (1.70 log units) below the measured one, outside the stated range (above it).
By their numbers in this assay, from the lowest: compound 2; then compound 1; then compound 3.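

In this assay, among these compounds, this place on the shared core turns out to be far less forgiving than the earlier compounds could show: 2-methylpyridin-3-yl in place of 2-chlorophenyl gives a 100-fold higher number from compound 2 to compound 3 (2.00 log units; beyond the scatter) even though both groups have the same heavy-atom count. Matching size alone therefore does not preserve the value here. By the atom count, the change removes a chlorine, adds a ring nitrogen and gains a hydrogen-bond acceptor, but no measurement on these compounds explains the size of the step.

Which part of the change matters most remains open, since the nitrogen and the methyl enter together. A 2-methylphenyl group or a 2-chloropyridin-3-yl group at this place would separate the two, and the plain pyridin-3-yl group would show what the ring nitrogen does alone.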